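Hydroxyphenyl replacing dichlorophenyl on the imine carbon

A few compounds are considered here, and "the series" means these few. Any claim that something is new, unique, unknown or untested is made for them only; others in the source may bear on it.

Three compounds share one core and differ in the aryl group on the imine carbon. In a functional assay on HT-29 cells (Homo sapiens) for cytotoxicity, read by MTT assay, with a stated time of 72 h (a higher number here means a weaker inhibitor, a lower number a stronger inhibitor), compound 1 `Cc1c(/N=C/c2ccc(N(C)C)cc2)c(=O)n(-c2ccccc2)n1C` gives 331000000 nM, compound 2 `Cc1c(/N=C/c2ccc(Cl)cc2)c(=O)n(-c2ccccc2)n1C` gives 309000000 nM and compound 3 `Cc1c(/N=C/c2ccc(Cl)cc2Cl)c(=O)n(-c2ccccc2)n1C` gives 178000000 nM. Compound 3 shows the lowest of the three numbers, but its separations from compound 2 and compound 1 both sit within the scatter. Compound 4 `Cc1c(/N=C/c2ccc(O)cc2)c(=O)n(-c2ccccc2)n1C` carries 4-hydroxyphenyl in place of 2,4-dichlorophenyl on a carbon with a double bond to nitrogen. Among the measured compounds shown here, no measured step covers a hydroxyl; the nearest are a 1.1-fold lower number from compound 1 to compound 2 (0.03 log units; within the scatter) and a 1.7-fold lower number from compound 2 to compound 3 (0.24 log units; within the scatter), neither beyond the scatter. Any step in this assay from compound 3 to compound 4 is therefore expected to stay within the scatter, a 1.4-fold higher number from compound 3 to compound 4 (0.15 log units; within the scatter). Compound 4 is estimated at 250000000 nM, range 100000000 nM to 600000000 nM.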

Compound 4, half-maximal inhibitory concentration: 389000000 nM
Beside the measured number, compound 4's estimate is 1.6-fold (0.19 log units) below it; measured number inside the range.
By their numbers in this assay, from the lowest: compounds 3, 2, 1 and 4 (each within the scatter of the next, the first and the last beyond it).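

Among the compounds shown here, replacing 2,4-dichlorophenyl with 4-hydroxyphenyl on the carbon with a double bond to nitrogen gives the only modest step beyond the scatter in this assay (a 2.2-fold higher number from compound 3 to compound 4 (0.34 log units; beyond the scatter)). Hydroxy in place of chloro (a 1.3-fold higher number from compound 2 to compound 4 (0.10 log units; within the scatter)) and in place of dimethylamino (a 1.2-fold higher number from compound 1 to compound 4 (0.07 log units; within the scatter)) both stay within the scatter, so only compound 3 and compound 4 are separated. No evidence here explains that separation.

Still open, on these data alone, is whether a carboxylic acid or a nitrile on the aromatic carbon would move the number beyond the scatter. A single chloro paired with hydroxy on the same aryl group also remains unresolved.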